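This account rests on a few compounds, and the source may have more. Where it says the series, first, only, none or still open, it means among the compounds named here.

In an ADME assay on microsomes from liver (Mus musculus, strain CD1) for metabolic stability, read by HPLC, using NADPH, with a stated time of 30 min (a higher number here means faster removal of the compound, a lower number slower removal), compound 1 `COc1cccc(NC(=O)c2nnn(CC3CCNCC3)c2N)c1` reads < 0.5 mL.min-1.g-1 as a limit of the assay and not a number. Among the compounds with values here, compound 2 `COc1cccc(NC(=O)c2nnn(Cc3ccc(OC(F)(F)F)cc3)c2N)c1` gives 2.9 mL.min-1.g-1 as the only true number so far. Compound 3 `COc1cccc(NC(=O)c2nnn(Cc3ccc(C4CC4)cc3)c2N)c1` carries cyclopropyl in place of trifluoromethoxy on an aromatic carbon, para to a large group (cyclopropyl in place of trifluoromethoxy on an aromatic carbon). Within the data shown here, no measured step covers this change, so only a small rise in this assay from the value of compound 2 (2.9 mL.min-1.g-1) is expected, within the scatter. The estimated step is a 1.4-fold higher number from compound 2 to compound 3 (0.14 log units; within the scatter) and stays small. Compound 3 is estimated at 4 mL.min-1.g-1 (expected range 1.8 mL.min-1.g-1 to 9 mL.min-1.g-1).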

Compound 3, intrinsic clearance in microsomes: 4.9 mL.min-1.g-1
For compound 3 the middle estimate is 1.2-fold (0.09 log units) below the measured one, and the stated range covers the measured number.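

Cyclopropyl in place of trifluoromethoxy on an aromatic carbon, para to a large group, gives a 1.7-fold higher number from compound 2 to compound 3 (0.23 log units; within the scatter) in this assay, so the two groups cannot be told apart at this position. At the saturated chain carbon bound to an aromatic nitrogen, 4-cyclopropylphenyl in place of piperidin-4-yl gives an at least 9.8-fold higher number from compound 1 to compound 3 (0.99 log units; beyond the scatter). Compound 1 reads as a limit of the assay and not a number, so this step has only a lower bound: the limit of < 0.5 mL.min-1.g-1 in this assay, at which 1 of the 3 values shown sits.

Open, from the compounds shown here alone, is whether a carboxylic acid or an amine on this aromatic carbon would move the number in this assay beyond the scatter.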